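A few compounds are considered here, and "the series" means these few. Any claim that something is new, unique, unknown or untested is made for them only; others in the source may bear on it.

Values in a functional assay on a cell-free system (Platelet, plasma, Homo sapiens) for inhibition; a higher number here means a weaker inhibitor, a lower number a stronger inhibitor:

compound 1 `O=C(Nc1ccc(OCc2ccc(F)cc2)cc1)C1CCCNC1`: 116000 nM
compound 2 `O=C(Nc1ccc(OCc2ccc(-c3ccccc3)cc2)cc1)C1CCCNC1`: 125000 nM
compound 3 `O=C(Nc1cccc(OCc2ccc(F)cc2)c1)C1CCNCC1`: 68000 nM

Compound 1 and compound 2 share a core and differ by phenyl in place of fluoro on an aromatic carbon. That change gave a 1.1-fold higher number from compound 1 to compound 2 (0.03 log units; within the scatter), so on this core it left the number where it was. Compound 3 has the same atoms as compound 1 joined differently; the difference between the two cores is not broken down here. The value of compound 3 lies close to those of compound 1 and compound 2, all three within the scatter of one another.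

Compound 4 `O=C(Nc1cccc(OCc2ccc(-c3ccccc3)cc2)c1)C1CCNCC1` is not yet measured in this assay. It differs from compound 3 by phenyl in place of fluoro on an aromatic carbon, the same change as that from compound 1 to compound 2, in the same place. Since that earlier step gave a 1.1-fold higher number from compound 1 to compound 2 (0.03 log units; within the scatter), the expectation for compound 4 is a step of similar size, a 1.1-fold higher number from compound 3 to compound 4 (0.04 log units; within the scatter), resting on that single prior step only. The estimate for compound 4 in this assay is therefore 75000 nM, with a range of 30000 nM to 180000 nM.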

Compound 4, half-maximal inhibitory concentration: 111000 nM
Compound 4: the middle estimate sits 1.5-fold (0.17 log units) below what was measured; the measured number falls inside the stated range.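

On the second core, phenyl in place of fluoro gave a 1.6-fold higher number from compound 3 to compound 4 (0.21 log units; within the scatter) in this assay, so the change again left the number within the scatter. The two steps do not differ from one another beyond what repeated measurements allow: the same change on two cores in this assay, a 1.1-fold higher number (0.03 log units; within the scatter) from compound 1 to compound 2 and a 1.6-fold higher number (0.21 log units; within the scatter) from compound 3 to compound 4, 1.5-fold (0.18 log units) apart, within the scatter of two such steps. This shows that the change behaves alike on these two cores, but only in the sense that neither step can be told from the scatter; it does not establish a real effect that transfers, and two cores say nothing about other cores in the series.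

On these data alone, only fluoro and phenyl appear at this place, para to a large group, so it remains open whether a carboxylic acid or a nitrile there would move the number beyond the scatter. The contribution of the difference between the two cores also remains open, since no pair shown isolates it in a single change.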